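The source may hold more compounds than are shown below. What is called first, only, known or untested is meant among the compounds shown, and "the series" means these compounds.

Measured so far in a functional assay on HeLa cells (Homo sapiens) for cytotoxicity, read by XTT assay, with a stated time of 24 h; on this read-out lower numbers stand for stronger inhibition and higher numbers for weaker inhibition:
compound 1, `Cc1cc(O)c2c(c1Cl)C(=O)C=CC2=O`, gives 13500 nM
compound 2, `CC(=O)Oc1cc(OC(C)=O)c2c(OC(C)=O)cc(C)c(Cl)c2c1OC(C)=O`, gives 52900 nM
compound 3, `CC(=O)Oc1c(C)cc(Cl)c2c1C(=O)C=CC2=O`, gives 21800 nM

Compound 3 stands second highest of the three numbers in this assay. Its nearest neighbour on the numbers is compound 1, whose value sits somewhat lower but within the usual scatter of the assay, so the two cannot be told apart. Compound 2 is the furthest, with a number that lies higher than that of compound 3 by more than the scatter. For the measured compounds named here, no single-point step between measured compounds is available in this set, so nothing can yet be said of how any one change moves the read-out.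

The next compound, compound 4, is `COc1c(C)cc(Cl)c2c1C(=O)C=CC2=O`. Against compound 3 the change is methyl in place of acetyl on an oxygen on an aromatic ring. The rest of the core of compound 3 is kept.

With no measured step of this kind in the series, the expectation for the change from compound 3 to compound 4 is a step of no more than the scatter, in either direction, and compound 4 is estimated at a 1.2-fold lower number from compound 3 to compound 4 (0.08 log units; within the scatter). Accordingly compound 4 is expected to give about 18000 nM in this assay, with a range from 7000 nM to 45000 nM.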

Compound 4, half-maximal inhibitory concentration: 41500 nM
The estimate for compound 4 lay 2.3-fold (0.36 log units) below the measured number, within the range that was stated.
By their numbers in this assay, from the lowest: compounds 1, 3, 4 and 2 (each within the scatter of the next, the first and the last beyond it).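

In this assay, the series now has its first single-point step: methyl in place of acetyl on an oxygen on an aromatic ring gives a 1.9-fold higher number from compound 3 to compound 4 (0.28 log units; within the scatter) and so cannot be told from no change at all. With the rest of the core of compound 3 kept, acetoxy and methoxy on this oxygen therefore read alike in this assay, although that statement rests on a single pair of compounds and does not extend to any other place on the core. Nothing at hand bears on why the two groups read alike.

The compounds shown leave open how a larger group on this oxygen would read, such as a butyl chain, a benzyl group, or a short chain ending in an amine or a carboxylic acid, and thus whether the tolerance seen for this one exchange holds beyond acetyl and methyl. They also leave open whether the same exchange gives a comparable step on an oxygen elsewhere on the core, or on the fully acetylated core of compound 2.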